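A few compounds are considered here, and "the series" means these few. Any claim that something is new, unique, unknown or untested is made for them only; others in the source may bear on it.

Three compounds have been measured in a functional assay on MCF7 cells (Homo sapiens) for inhibition, read by MTT assay, with a stated time of 48 h; a higher number here means a weaker inhibitor, a lower number a stronger inhibitor:

Compound 1, `CCOC(=O)C1=C(N/C=N/c2nnc(S(N)(=O)=O)s2)Nc2[nH]nc(C)c2C1c1ccc(N(C)C)cc1`, gives 34500 nM.
Compound 2, `CCOC(=O)C1=C(NN=C(C(C)=O)C(C)=O)Nc2[nH]nc(C)c2C1c1ccc(N(C)C)cc1`, gives 9740 nM.
Compound 3, `CCOC(=O)C1=C(N/N=C(/Cl)C#N)Nc2[nH]nc(C)c2C1c1ccc(N(C)C)cc1`, gives 23200 nM.

Compound 3 stands second highest of these three numbers. Its nearest neighbour is compound 1, with a 1.5-fold lower number from compound 1 to compound 3 (0.17 log units; within the scatter); compound 2 sits furthest away, with a 2.4-fold higher number from compound 2 to compound 3 (0.38 log units; beyond the scatter).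

Compound 4, `CCOC(=O)C1=C(N/N=C(/C(=O)Br)c2ccc(Br)cc2)Nc2[nH]nc(C)c2C1c1ccc(N(C)C)cc1`, differs from compound 3 in one place: a group of 12 heavy atoms (8 carbon, 1 nitrogen, 1 oxygen, 2 bromine; one six-membered aromatic ring of carbon only) in place of a group of 5 heavy atoms (2 carbon, 2 nitrogen, 1 chlorine; no ring), on an amine nitrogen. All three measured steps change the same group on this amine nitrogen, and none moved the number by more than a modest amount; a 3.5-fold lower number from compound 1 to compound 2 (0.55 log units; beyond the scatter) is the largest. A similarly modest step is therefore expected here, toward a lower number, as a 1.5-fold lower number from compound 3 to compound 4 (0.19 log units; within the scatter). Compound 4 is estimated at 15000 nM, with a range from 5000 nM to 45000 nM.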

Compound 4, half-maximal inhibitory concentration: 61300 nM
Estimate against measurement, compound 4: 4.1-fold (0.61 log units) below; the measured number lies above the stated range.
By their numbers in this assay, from the lowest: compound 2; then compounds 3, 1 and 4 (each within the scatter of the next, the first and the last beyond it).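

Putting the largest group so far on this amine nitrogen, one with a six-membered aromatic ring of carbon only, does not lower the number: the result is a 2.6-fold higher number from compound 3 to compound 4 (0.42 log units; beyond the scatter). The spread at this position also widens, with a 6.3-fold higher number from compound 2 to compound 4 (0.80 log units; beyond the scatter) now the largest step, while a 1.8-fold higher number from compound 1 to compound 4 (0.25 log units; within the scatter) leaves the two ring-bearing groups within the scatter of each other. Nothing available here explains these differences. On these data alone, whether the ring or the bromine atoms matter remains open: a plain phenyl group, or a carboxylic acid in place of the carbonyl bromide, would help separate them.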